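This account rests on a few compounds, and the source may have more. Where it says the series, first, only, none or still open, it means among the compounds named here.

Working notes on the series.

Three compounds carry numbers in a functional assay on PC-3 cells (Homo sapiens) for cytotoxicity, read by MTT assay, with a stated time of 24 h; on this read-out lower numbers stand for stronger inhibition and higher numbers for weaker inhibition. Compound 1 `O=C1/C(=C/c2ccccc2F)CN(Cc2cn(Cc3ccc(F)cc3)nn2)C/C1=C\c1ccccc1F` gives 19400 nM. Compound 2 `Cc1ccc(/C=C2\CN(Cc3cn(Cc4cccc(Cl)c4)nn3)C/C(=C\c3ccc(C)cc3)C2=O)cc1` gives 29300 nM. Compound 3 `Cc1ccc(/C=C2\CN(Cc3cn(Cc4ccccc4Cl)nn3)C/C(=C\c3ccc(C)cc3)C2=O)cc1` gives 8900 nM, the lowest of the three numbers; its nearest neighbour is compound 1 and its furthest is compound 2, both gaps beyond the scatter. Among the measured compounds shown here, the only single-point step so far, a 3.3-fold lower number from compound 2 to compound 3 (0.52 log units; beyond the scatter), shows that moving the chlorine on the phenyl that sits on the saturated chain carbon bound to the aromatic nitrogen changes the read-out by a modest but real amount.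

Compound 4 `Cc1ccc(/C=C2\CN(Cc3cn(Cc4ccc(F)cc4)nn3)C/C(=C\c3ccc(C)cc3)C2=O)cc1` is the next member. Its difference from compound 3 is 4-fluorophenyl in place of 2-chlorophenyl on a saturated chain carbon bound to an aromatic nitrogen. For the measured compounds named here, no measured step matches this change on the same core: compound 1 also carries a 4-fluorophenyl at this place, but its core differs, so its value can only be read as a rough pointer. Because compound 1 gives 19400 nM and the step of a 3.3-fold lower number from compound 2 to compound 3 (0.52 log units; beyond the scatter) shows that leaving the 2-chlorophenyl costs potency, the expectation for compound 4 is a somewhat higher number than compound 3, a step of about a 2.0-fold higher number from compound 3 to compound 4 (0.31 log units; beyond the scatter), though a result within the scatter is not excluded. Compound 4 is estimated at 18000 nM, within a range of 7000 nM to 45000 nM.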

Compound 4, half-maximal inhibitory concentration: 65600 nM
Compound 4: the middle estimate sits 3.6-fold (0.56 log units) below what was measured; measured number outside the range, above it.
By their numbers in this assay, from the lowest: compound 3; then compounds 1 and 2 (each within the scatter of the next); then compound 4.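

In this assay, the place on a saturated chain carbon bound to an aromatic nitrogen responds to the choice of aryl group more widely than the chlorine move alone showed: 4-fluorophenyl in place of 2-chlorophenyl gives a 7.4-fold higher number from compound 3 to compound 4 (0.87 log units; beyond the scatter), and 4-fluorophenyl in place of 3-chlorophenyl gives a 2.2-fold higher number from compound 2 to compound 4 (0.35 log units; beyond the scatter). On the shared core, the three groups therefore give separated numbers, running from 2-chlorophenyl in compound 3 through 3-chlorophenyl in compound 2 to 4-fluorophenyl in compound 4, with every step beyond the scatter and none of these three compounds going against that order. No measurement offered alongside these cell numbers bears on the reason for this result.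

Each step to compound 4 changes the halogen and its printed ring position together, so the compounds shown leave the two contributions unseparated, and a 4-chlorophenyl at this place on the shared core would be the direct test. Also open, from the compounds shown here alone, is whether a group of another kind here, such as a carboxylic acid or an amine on the phenyl, would extend or break this order.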